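Swapping Phenyl for 1H-pyrrol-2-yl at the Assay's Limit

The source may hold more compounds than are shown below. What is called first, only, known or untested is meant among the compounds shown, and "the series" means these compounds.

The measurements come from a functional assay on WRL68 cells (Homo sapiens) for cytotoxicity, read by MTT assay, with stated times of 6 h and 48 h (on this read-out lower numbers stand for stronger inhibition and higher numbers for weaker inhibition), and cover three compounds that share a core. Compound 1 `Cn1c(/C=C/C(=O)c2ccccc2O)cc(Br)c1Br` gives 330 nM in this assay and has a number to stand on. Compound 2 `Cn1c(/C=C/C(=O)c2ccc(O)cc2)cc(Br)c1Br` gives 1910 nM in the same test.

Compound 3 `Cn1c(-c2cc(-c3ccccc3)no2)cc(Br)c1Br` is different: its reading of >= 100000 nM is a limit of the assay and not a number.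

Compound 4 `Cn1c(-c2cc(-c3ccc[nH]3)no2)cc(Br)c1Br` has not been measured yet. It changes one group of compound 3: 1H-pyrrol-2-yl in place of phenyl on an aromatic carbon, which puts 1H-pyrrol-2-yl in place of phenyl on an aromatic carbon of the five-membered aromatic ring with 1 nitrogen and 1 oxygen. Within the data shown here, no measured pair shows this change, so compound 3 is the nearest guide.

For compound 3 the reading >= 100000 nM is only a limit, so compound 4 is expected to stay close to it. The estimated move is an at least 1.4-fold lower number from compound 3 to compound 4 (0.15 log units; that floor lies within the scatter) and would point, if it shows at all, toward stronger inhibition. The estimate for compound 4 is 70000 nM within an expected range of 20000 nM to 150000 nM and the assay may again report only a limit.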

Compound 4, half-maximal inhibitory concentration: >= 100000 nM
Compound 4: no number, only a limit (the forecaster's own chance of this, stated with the estimate: 55%); middle value at least 1.4-fold (0.15 log units) away from the limit.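

Compound 3 and compound 4 each give only a limit and not a number, so no step can be read between them: the limit of >= 100000 nM in this assay, at which 2 of the 4 values shown sit.

The compounds shown leave open whether 1H-pyrrol-2-yl in place of phenyl changes the cytotoxicity reading at all.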